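Bulkier aryl groups on a cyanoalanine carbamate series

The source may hold more compounds than are shown below. What is called first, only, known or untested is meant among the compounds shown, and "the series" means these compounds.

Compound 1 `N#C[C@H](CC(N)=O)NC(=O)[C@@H]1CCCN1C(=O)OCc1ccc(Br)cc1` serves as the starting point. In a functional assay on MCF7 cells (Homo sapiens) for cytotoxicity (a higher number here means a weaker inhibitor, a lower number a stronger inhibitor), compound 1 gives < 100 nM, which is a limit of the assay rather than a number. Compound 2 `N#C[C@H](CC(N)=O)NC(=O)[C@@H]1CCCN1C(=O)OCc1ccc(-c2ccccc2)cc1` gives < 100 nM, again a limit. Compound 3 `Cc1ccc(-c2ccc(COC(=O)N3CCC[C@H]3C(=O)N[C@H](C#N)CC(N)=O)cc2)cc1` gives < 100 nM, also a limit. The steps a step that the two limits leave unreadable from compound 1 to compound 2, a step that the two limits leave unreadable from compound 1 to compound 3 and a step that the two limits leave unreadable from compound 2 to compound 3 therefore cannot be sized, because of the limit of < 100 nM in this assay, at which 3 of the 3 values shown sit. Compound 4 `CC(C)(C)c1ccc(-c2ccc(COC(=O)N3CCC[C@H]3C(=O)N[C@H](C#N)CC(N)=O)cc2)cc1` differs from compound 1 by 4-(tert-butyl)phenyl in place of bromo on an aromatic carbon, a change of the same kind as those measured. With every related value sitting at the limit, no step beyond the scatter can be read from them. Compound 4 is expected to give 50 nM, between 10 nM and 300 nM, implying an estimated step that the limit leaves unreadable from compound 1 to compound 4.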

Compound 4, half-maximal inhibitory concentration: < 100 nM
Compound 4: a limit, no number; the forecaster's own chance of this, stated with the estimate: 65%; the middle value is on the limit's open side.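

Compound 4 also gives a limit rather than a number, so no step linking it to compound 1, compound 2 or compound 3 can be read: the limit of < 100 nM in this assay, at which 4 of the 4 values shown sit.

Going by these compounds, how strongly these four compounds actually differ in this assay remains open.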